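This account rests on a few compounds, and the source may have more. Where it says the series, first, only, none or still open, it means among the compounds named here.

For the measured compounds named here, compound 1 `COc1ccc(C2N=C(SCc3ccc(Cl)cc3)NC(C)=C2C(=O)Nc2ccc(F)cc2)cc1OC` is the first of three measured analogues. In a functional assay on the whole organism (artery, strain albino) with Rattus norvegicus as the target, with a stated time of 240 min, at a dose of 10 mg/kg by the oral route (a higher number here means more inhibition at the dose given (going by the name of the read-out), a lower number less inhibition), compound 1 gives 24.1%. Compound 2 `COc1ccc(C2N=C(SCc3ccc(F)cc3)NC(C)=C2C(=O)Nc2ccc(F)cc2)cc1OC` differs from it by fluoro in place of chloro on an aromatic carbon. In this assay compound 2 gives 28.7%. That change made a step of a number 4.6 percentage points higher from compound 1 to compound 2 (within the scatter). Compound 3 `COc1ccc(C2N=C(SCc3ccc(Cl)cc3)NC(C)=C2C(=O)Nc2ccc(Br)cc2)cc1` gives 29.2% in this assay. The difference between the core of compound 1 and the core of compound 3 is not broken down here, and the values of compound 3 and compound 2 lie within the scatter of each other. Going by the values given here, compound 4 `COc1ccc(C2N=C(SCc3ccc(F)cc3)NC(C)=C2C(=O)Nc2ccc(Br)cc2)cc1` is not yet measured; it differs from compound 3 by fluoro in place of chloro on an aromatic carbon, the same change as the one made from compound 1 to compound 2. The step is expected to stay small, about a number 2.8 percentage points higher from compound 3 to compound 4 (within the scatter), because the earlier instance of this change gave a number 4.6 percentage points higher from compound 1 to compound 2 (within the scatter). Compound 4 is therefore estimated at 32%, with a range from 18% to 46%.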

Compound 4, a percentage reported as inhibition, in the whole organism at one dose (the size of the read-out at that dose, not a potency): 22.1%
Compound 4: middle estimate off by 9.9 percentage points, on the high side; measured number inside the range.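

Fluoro in place of chloro, (4-chlorobenzyl)sulfanyl to (4-fluorobenzyl)sulfanyl, gives a number 7.1 percentage points lower from compound 3 to compound 4 (within the scatter) in this assay. Set beside the same change on the other core, the two steps do not separate: the same change on two cores in this assay, a number 4.6 percentage points higher (within the scatter) from compound 1 to compound 2 and a number 7.1 percentage points lower (within the scatter) from compound 3 to compound 4, 11.7 percentage points apart, within the scatter of two such steps. So the change moves the number by no more than the scatter on either core, and the opposite signs carry no weight; this neither shows that a step carries over from one core to the other nor that the two cores respond differently.

The compounds shown vary this group only between chloro and fluoro. Open, from the compounds shown here alone, is whether an amine or a carboxylic acid on that aromatic ring, or a longer chain in place of the benzyl group, would give a step beyond the scatter.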